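Rearranging Methoxy Groups on the Chalcone Aryl Ring

A few compounds are considered here, and "the series" means these few. Any claim that something is new, unique, unknown or untested is made for them only; others in the source may bear on it.

Measured compounds:
compound 1 `COc1ccc(-c2cc3ccccc3nc2/C=C/C(=O)c2ccccc2)cc1` — 6670 nM
compound 2 `COc1ccc(-c2cc3ccccc3nc2/C=C/C(=O)c2c(OC)cccc2OC)cc1` — 6630 nM

Both compounds were tested in a functional assay on NCI-H460 cells (Homo sapiens) for antiproliferative activity, read by XTT assay, with a stated time of 72 h; on this read-out higher numbers stand for weaker inhibition and lower numbers for stronger inhibition. Compound 1, whose carbonyl carbon carries a plain phenyl, gives 6670 nM. Compound 2, which carries 2,6-dimethoxyphenyl on the same carbonyl carbon, gives 6630 nM. For the measured compounds named here, the only step available, a 1.0-fold lower number from compound 1 to compound 2 (0.00 log units; within the scatter), shows that adding two methoxy groups to this ring left the number essentially unchanged. Compound 2 has the lowest of the two numbers, but its step to compound 1 is within the scatter, so the two cannot be ranked.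

Compound 3 `COc1ccc(-c2cc3ccccc3nc2/C=C/C(=O)c2ccc(OC)c(OC)c2)cc1` has not been measured. It differs from compound 2 in one place: 3,4-dimethoxyphenyl in place of 2,6-dimethoxyphenyl on a carbonyl carbon. The same atoms are present, only arranged differently on the aryl ring attached to the carbonyl carbon. Going by the values given here, no measured step covers this rearrangement; the one step that concerns this ring, from compound 1 to compound 2, showed no change beyond the scatter. The expectation for a 1.2-fold lower number from compound 2 to compound 3 (0.08 log units; within the scatter) is therefore a small step, with no clear direction. Compound 3 is expected to give 5500 nM, with a range from 1800 nM to 16000 nM.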

Compound 3, half-maximal inhibitory concentration: 7540 nM
Compound 3: the middle estimate sits 1.4-fold (0.14 log units) below what was measured, and the stated range covers the measured number.
By their numbers in this assay, from the lowest: compounds 2, 1 and 3 (each within the scatter of the next).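

In this assay, putting 3,4-dimethoxyphenyl in place of 2,6-dimethoxyphenyl on the carbonyl carbon gives a 1.1-fold higher number from compound 2 to compound 3 (0.06 log units; within the scatter) and so shows what the earlier pair could not: with the same atoms on this ring, these two arrangements of the methoxy groups cannot be told apart in this assay. Against the plain phenyl, 3,4-dimethoxyphenyl gives a 1.1-fold higher number from compound 1 to compound 3 (0.05 log units; within the scatter) and thus joins 2,6-dimethoxyphenyl in showing no separation from the ring without methoxy groups, so neither of the two dimethoxy patterns shown can be ranked against phenyl at this place. Nothing available offers an explanation for this flat result.

All three rings shown carry either no added group or two methoxy groups, so it remains open whether a different kind of group on this ring, such as an amine, a carboxylic acid or a longer chain like butoxy, would shift the number beyond the scatter. On these data alone, it also remains open whether a single methoxy group, or three of them, would behave like the rings compared here.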